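The source may hold more compounds than are shown below. What is called first, only, known or untested is meant among the compounds shown, and "the series" means these compounds.

Working notes on the series. In a functional assay on C6 cells (Rattus norvegicus) for cytotoxicity, read by MTT assay, with a stated time of 24 h, tested at 25 ug/mL (on this read-out higher numbers stand for a weaker effect at the one concentration tested and lower numbers for a stronger effect), compound 1 `Cn1nnnc1SCC(=O)N/N=c1/scc(-c2ccccc2)n1-c1ccccc1` gives 64.2%; compound 2 `Cn1nnnc1SCC(=O)N/N=c1/scc(-c2ccc([N+](=O)[O-])cc2)n1-c1ccccc1` gives 69.3%; compound 3 `Cc1ccc(-c2cs/c(=N/NC(=O)CSc3nncn3C)n2-c2ccccc2)cc1` gives 70.7%. Compound 3 stands highest of the three numbers, nearest to compound 2 and furthest from compound 1, both gaps within the scatter. For the measured compounds named here, the one counted step, a number 5.1 percentage points higher from compound 1 to compound 2 (within the scatter), also lies within the scatter. Compound 4 `Cc1ccc(-c2cs/c(=N/NC(=O)CSc3nnnn3C)n2-c2ccccc2)cc1` differs from compound 3 by 1-methyl-1H-tetrazol-5-yl in place of 4-methyl-4H-1,2,4-triazol-3-yl on a sulfur. Going by the values given here, no measured step isolates this change; compound 1 carries the tetrazole but differs from compound 3 in two places, and their two values show no gap beyond the scatter. No step beyond the scatter is therefore expected in this assay. For compound 4 the expected value is 66%, within 55% to 77%, an expected step of a number 4.7 percentage points lower from compound 3 to compound 4 (within the scatter).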

Compound 4, a percentage reported as activity, at one concentration (the size of the read-out at that concentration, not a potency): 60.7%
Compound 4: middle estimate off by 5.3 percentage points, on the high side; the measured number falls inside the stated range.
By their numbers in this assay, from the lowest: compounds 4, 1, 2 and 3 (each within the scatter of the next).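

The change on the sulfur now has a measured step of its own in this assay and reads a number 10 percentage points lower from compound 3 to compound 4 (within the scatter) so 1-methyl-1H-tetrazol-5-yl does not separate from 4-methyl-4H-1,2,4-triazol-3-yl here. Methyl in place of nitro on the aromatic carbon reads a number 8.6 percentage points lower from compound 2 to compound 4 (within the scatter) and methyl in place of hydrogen reads a number 3.5 percentage points lower from compound 1 to compound 4 (within the scatter) so neither change on that carbon separates either.

As far as these compounds go, whether an amine or a carboxylic acid on that aromatic carbon would give a step beyond the scatter stays open. Nothing available bears on the reason for these steps.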